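The compounds below may be only part of what the source reports. "The series", "measured", "known", "first", "only" and "open" are said of these compounds alone.

Measured so far:
compound 1 `Cn1c(NN)nc(-c2ccco2)c(C#N)c1=O` — 65 ug/mL
compound 2 `Cn1c(NN)nc(-c2ccc(Cl)cc2)c(C#N)c1=O` — 59 ug/mL
compound 3 `CCOC(=O)c1cnn(-c2nc(-c3ccc(OC)cc3)c(C#N)c(=O)n2C)c1N` — 79 ug/mL

All three were run in a functional assay, with a stated time of 150 min; a lower number here means a stronger inhibitor, a higher number a weaker inhibitor. Compound 3 gives the highest of the three numbers, but its gaps to compound 1 and to compound 2 both lie within the scatter, so the three cannot be ordered against each other.

Compound 4 `CCOC(=O)c1cnn(-c2nc(-c3cccc(OC)c3OC)c(C#N)c(=O)n2C)c1N` is not yet measured. Against compound 3 the change is 2,3-dimethoxyphenyl in place of 4-methoxyphenyl on an aromatic carbon. For the measured compounds named here, no pair of measured compounds isolates a change of this kind, and the three numbers sit close together across different groups on the shared core, so no step beyond the scatter is expected in either direction. Compound 4 is expected to give about 80 ug/mL in this assay, the expected step being a 1.0-fold higher number from compound 3 to compound 4 (0.01 log units; within the scatter), with a range from 40 ug/mL to 160 ug/mL.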

Compound 4, half-maximal inhibitory concentration: 69 ug/mL
Compound 4: middle estimate off by 1.2-fold (0.06 log units), on the high side; the range from low to high includes it.
By their numbers in this assay, from the lowest: compounds 2, 1, 4 and 3 (each within the scatter of the next).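

In this assay, for the compounds shown here, 2,3-dimethoxyphenyl in place of 4-methoxyphenyl on this aromatic carbon gives a 1.1-fold lower number from compound 3 to compound 4 (0.06 log units; within the scatter), the first step that isolates one place. The step lies within the scatter, so this swap shows no readable effect on the number, even with the extra methoxy group. Nothing available bears on this result.

From the compounds shown here alone, whether a different kind of group here, such as an amine or a carboxylic acid, would give a step beyond the scatter stays open. Going by these compounds alone, with every number so far within the scatter, no feature of the series can yet be tied to inhibition.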